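Amine chain variation on the shared core, heart dose

The source may report more compounds than this note shows. Statements on the series, on what has been measured and on what is new or still open speak of the compounds shown alone.

The series keeps one core and varies the chain on the oxygen of the aromatic ring. Going by the values given here, compound 1 `CC(=O)/C(=C\c1ccccc1)Oc1ccccc1OCC(O)CNC(C)(C)C` carries the 1-hydroxy-2-((tert-butyl)amino)ethyl chain; in a functional assay on the whole organism (heart) with Rattus norvegicus as the target (a lower number here means that less compound is needed, a higher number that more compound is needed for the effect), compound 1 gives 1.9 mg/kg, the highest of the two numbers measured so far. Compound 2 `CC(=O)/C(=C\c1ccccc1)Oc1ccccc1OCC(C)N(C)C` carries the 1-(dimethylamino)ethyl chain, and in this assay compound 2 gives 0.9 mg/kg. Among the compounds with values here, the single measured step, a 2.1-fold lower number from compound 1 to compound 2 (0.32 log units; beyond the scatter), is the only guide the series offers.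

Compound 3 `CC(=O)/C(=C\c1ccccc1)Oc1ccccc1OCCCN(C(C)C)C(C)C` is the next member. Its change from compound 1 is 2-(diisopropylamino)ethyl in place of 1-hydroxy-2-((tert-butyl)amino)ethyl on a saturated chain carbon bound to an oxygen on an aromatic ring. As in the step to compound 2, the 1-hydroxy-2-((tert-butyl)amino)ethyl chain leaves and a tertiary amine chain enters, so the step of a 2.1-fold lower number from compound 1 to compound 2 (0.32 log units; beyond the scatter) bears on it most directly and points to a modestly lower number rather than a higher one; the entering 2-(diisopropylamino)ethyl chain matches neither measured chain, so the expectation stays near that measured step rather than beyond it. From compound 1 the expected step is a 1.6-fold lower number from compound 1 to compound 3 (0.20 log units; within the scatter). In this assay compound 3 is therefore estimated at 1.2 mg/kg, with a range from 0.5 mg/kg to 3 mg/kg.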

Compound 3, dose for half-maximal effect: 0.1 mg/kg
Compound 3: middle estimate off by 12-fold (1.08 log units), on the high side; the whole stated range lies above it.
By their numbers in this assay, from the lowest: compound 3; then compound 2; then compound 1.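

In this assay, the position on a saturated chain carbon bound to an oxygen on an aromatic ring proves far more responsive than the earlier comparison showed: a 19-fold lower number from compound 1 to compound 3 (1.28 log units; beyond the scatter) is a large step, whereas a 2.1-fold lower number from compound 1 to compound 2 (0.32 log units; beyond the scatter) is a modest one. Replacing the 1-hydroxy-2-((tert-butyl)amino)ethyl chain with a tertiary amine chain therefore does not fix the number by itself, and the identity of the entering chain matters, with a 9.0-fold lower number from compound 2 to compound 3 (0.95 log units; beyond the scatter) separating the two tertiary amine chains. The data shown give no measurement that accounts for this gap.

Compound 3 differs from compound 2 both in the groups on the nitrogen and in the chain that carries them, so a 2-(dimethylamino)ethyl chain is the comparison that would separate these two contributions. As far as these compounds go, it also remains open whether a 2-(diethylamino)ethyl chain, a piperidine on the same chain or a longer chain ending in diisopropylamino would keep the number as low as that of compound 3.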